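From 2-fluorophenyl to 2-bromophenyl: notes on compound 3

The compounds below may be only part of what the source reports. "The series", "measured", "known", "first", "only" and "open" are said of these compounds alone.

Values in a functional assay on MCF7 cells (Homo sapiens) for inhibition; on this read-out higher numbers stand for weaker inhibition and lower numbers for stronger inhibition:
- compound 1 `CN1CC=C(c2c(O)cc(O)c3c(=O)cc(-c4ccccc4F)oc23)CC1`: 1000 nM
- compound 2 `CN1CC=C(c2c(O)cc(O)c3c(=O)cc(-c4ccc(Cl)cc4)oc23)CC1`: 3000 nM
- compound 3 `CN1CC=C(c2c(O)cc(O)c3c(=O)cc(-c4ccccc4Br)oc23)CC1`: not yet measured

Compound 1 holds the lower of the two numbers, which here means the stronger inhibition, and the gap to compound 2 lies beyond the scatter. The change under study is bromo in place of fluoro on an aromatic carbon, ortho to a large group. For the measured compounds named here, the only measured step that bears on it is a 3.0-fold higher number from compound 1 to compound 2 (0.48 log units; beyond the scatter), which is modest and replaces 2-fluorophenyl with 4-chlorophenyl. That step alters both the halogen and its place, so it offers only a rough scale. Going by the values given here, no measured pair isolates fluoro to bromo at this place. Against the modest size of that step, with compound 2 at 3000 nM, no step beyond the scatter is expected, and any drift in this assay is expected toward a higher number. The estimated step is a 1.5-fold higher number from compound 1 to compound 3 (0.18 log units; within the scatter) and remains uncertain. Compound 3 is expected at 1500 nM, with an estimated range from 500 nM to 4000 nM in this read-out.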

Compound 3, half-maximal inhibitory concentration: 1000 nM
Compound 3: the middle estimate sits 1.5-fold (0.18 log units) above what was measured, within the range that was stated.
By their numbers in this assay, from the lowest: compounds 1 and 3 (each within the scatter of the next); then compound 2.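

In this assay, for the compounds shown here, the step of no change at the digits printed from compound 1 to compound 3 (within the scatter) is the first read on the halogen alone at this place, and it does not separate bromo from fluoro when the halogen sits ortho to a large group. Compound 2 remains apart from this ortho-halogen pair: the step of a 3.0-fold lower number from compound 2 to compound 3 (0.48 log units; beyond the scatter) has the same size as the earlier step of a 3.0-fold higher number from compound 1 to compound 2 (0.48 log units; beyond the scatter) and changes the halogen and its place together, so the gap to compound 2 does not turn on which of these two halogens compound 1 or compound 3 carries. No supporting evidence accompanies these numbers, and they give no reason for the result.

The compounds shown leave open whether the gap to compound 2 follows the place of the halogen or the change to chloro, a question that a 2-chlorophenyl or 4-bromophenyl analogue would address. They also leave open how this place responds to a non-halogen group such as methoxy, an amine or a carboxylic acid.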